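Adding a Chloro to Compound 3

The compounds below may be only part of what the source reports. "The series", "measured", "known", "first", "only" and "open" are said of these compounds alone.

Three compounds have numbers in a functional assay on the whole organism for inhibition, with Mus musculus as the target; a higher number here means that more compound is needed for the effect, a lower number that less compound is needed. Compound 1 `CN1Cc2c(N)cccc2C(c2ccc(Cl)cc2)C1` gives 1.6 mg/kg. Compound 2 `CCCCNC(=O)Nc1cccc2c1CN(C)CC2c1ccc(Cl)cc1` gives 44 mg/kg. Compound 3 `CCOC(=O)Nc1cccc2c1CN(C)CC2c1ccccc1` gives 3.2 mg/kg. Compound 3 thus lies within the scatter of compound 1, while compound 2 needs more compound than compound 3, a gap beyond the scatter.

The unmeasured compound 4 `CCOC(=O)Nc1cccc2c1CN(C)CC2c1ccc(Cl)cc1` differs from compound 3 by a single change, chloro in place of hydrogen on an aromatic carbon, which turns phenyl into 4-chlorophenyl.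

Within the data shown here, only one measured step is available, a 28-fold higher number from compound 1 to compound 2 (1.44 log units; beyond the scatter). It is large, but it is butylcarbamoyl in place of hydrogen on a nitrogen on an aromatic ring, so it says nothing direct about the chloro. Among the measured compounds shown here, no measured pair isolates that change. Compound 1 and compound 2 both carry 4-chlorophenyl, yet their values lie far apart. The expectation therefore rests on compound 3 itself at 3.2 mg/kg, and no step beyond the scatter is expected in this assay. The expected change is a 1.1-fold lower number from compound 3 to compound 4 (0.03 log units; within the scatter), which would stay within the scatter. Compound 4 is estimated at 3 mg/kg, with an expected range from 1 mg/kg to 10 mg/kg.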

Compound 4, dose for half-maximal effect: 4.8 mg/kg
Beside the measured number, compound 4's estimate is 1.6-fold (0.20 log units) below it; low and high end bracket the measured number.
By their numbers in this assay, from the lowest: compounds 1, 3 and 4 (each within the scatter of the next, the first and the last beyond it); then compound 2.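

In this assay, the chloro on the phenyl ring can now be read on its own (a 1.5-fold higher number from compound 3 to compound 4 (0.18 log units; within the scatter)), and this change at the carbon para to a large group stays within the scatter. With 4-chlorophenyl held constant, the group on the aromatic nitrogen emerges as the place where the number moves beyond the scatter, both for ethoxy in place of butylamino on the carbonyl carbon (a 9.2-fold lower number from compound 2 to compound 4 (0.96 log units; beyond the scatter)) and for ethoxycarbonyl in place of hydrogen on the nitrogen (a 3.0-fold higher number from compound 1 to compound 4 (0.48 log units; beyond the scatter)). No evidence in hand accounts for any of these steps.

On these data alone, whether the same place on the phenyl ring would also accept a larger or different group, such as bromo, methoxy or trifluoromethyl, remains open, since a single chloro speaks only for itself. As far as these compounds go, it is also open how a longer chain in place of ethoxy on the carbonyl carbon, or an acetyl group on the aromatic nitrogen, would fall relative to the ethoxycarbonyl and butylcarbamoyl groups.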